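The compounds below may be only part of what the source reports. "The series", "measured", "known", "first", "only" and "open" are said of these compounds alone.

Measured so far in a functional assay on MCF7 cells (Homo sapiens) for antiproliferative activity, read by MTT assay, with a stated time of 48 h; on this read-out higher numbers stand for weaker inhibition and lower numbers for stronger inhibition: compound 1 `COc1ccc(/C=C/C(=O)Nc2nnc(-c3ccc(C)cc3)s2)cc1` gives 0.35 ug/mL; compound 2 `Cc1ccc(/C=C/C(=O)Nc2nnc(-c3ccc(C)cc3)s2)cc1` gives 0.61 ug/mL; compound 3 `Cc1ccc(-c2nnc(NC(=O)/C=C/c3ccccc3)s2)cc1` gives 1.19 ug/mL.

Compound 4 `COc1ccc(-c2nnc(NC(=O)/C=C/c3ccccc3)s2)cc1` is not yet measured. It differs from compound 3 by methoxy in place of methyl on an aromatic carbon. The same change separates compound 2 from compound 1, as methoxy in place of methyl on an aromatic carbon, and there it gave a 1.7-fold lower number from compound 2 to compound 1 (0.24 log units; within the scatter). The two cores on which the change is made differ by hydrogen in place of methyl on an aromatic carbon. Compound 3 stands with a 2.0-fold higher number from compound 2 to compound 3 (0.29 log units; within the scatter) and with a 3.4-fold higher number from compound 1 to compound 3 (0.53 log units; beyond the scatter). Only one earlier instance of the change exists among these compounds, so the expectation rests on that single step alone. For compound 4 the expected step is a 1.7-fold lower number from compound 3 to compound 4 (0.23 log units; within the scatter) because the same change gave a 1.7-fold lower number from compound 2 to compound 1 (0.24 log units; within the scatter). The estimate for compound 4 in this assay is 0.7 ug/mL, with a likely range from 0.35 ug/mL to 1.4 ug/mL.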

Compound 4, half-maximal inhibitory concentration: 0.78 ug/mL
Estimate against measurement, compound 4: 1.1-fold (0.05 log units) below; measured number inside the range.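

In this assay, methoxy in place of methyl on an aromatic carbon gives a 1.5-fold lower number from compound 3 to compound 4 (0.18 log units; within the scatter), and the step carries from one core to the other with no difference beyond the scatter: the same change on two cores in this assay, a 1.7-fold lower number (0.24 log units; within the scatter) from compound 2 to compound 1 and a 1.5-fold lower number (0.18 log units; within the scatter) from compound 3 to compound 4, 1.1-fold (0.06 log units) apart, within the scatter of two such steps.

Each step lies within the scatter, so the pair shows a consistent result for the change across these cores, but it does not establish that methoxy truly lowers the number relative to methyl on either core. The evidence is two instances on cores that differ only by hydrogen in place of methyl on an aromatic carbon, and it does not extend to cores that differ more widely.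

Open, from the compounds shown here alone, is how an amine, a carboxylic acid or a longer chain such as butoxy would compare with methyl and methoxy at this place. Also open, going by these compounds, is whether the same step would hold on cells other than these.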